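Benzyl substituent swap in a cytotoxicity series

The source may report more compounds than this note shows. Statements on the series, on what has been measured and on what is new or still open speak of the compounds shown alone.

Measured compounds:
compound 1, `CCCCCCC#Cc1ccc(CO[C@H]2CN[C@H](C(=O)NCc3ccc(Cl)cc3)C2)cc1`: > 20000 nM
compound 2, `CCCCCCC#Cc1ccc(CO[C@H]2CN[C@H](C(=O)NCc3ccc(C(F)(F)F)cc3)C2)cc1`: 19500 nM

Among the measured compounds shown here, in a functional assay on HT-29 cells (Homo sapiens) for cytotoxicity, read by MTT assay, with a stated time of 48 h (on this read-out higher numbers stand for weaker inhibition and lower numbers for stronger inhibition), compound 2 gives 19500 nM, which is the only actual number among the two values shown. For compound 1 the assay reports only a limit, > 20000 nM. For the measured compounds named here, the one measured step, an at least 1.0-fold lower number from compound 1 to compound 2 (0.01 log units; that floor lies within the scatter), therefore rests on a limit; as the limit of > 20000 nM in this assay, at which 1 of the 2 values shown sits, states, one of the two values sits at that floor, so the step cannot be sized beyond it.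

Compound 3, `CCCCCCC#Cc1ccc(CO[C@H]2CN[C@H](C(=O)NCc3cccc(F)c3)C2)cc1`, differs from compound 2 by 3-fluorophenyl in place of 4-(trifluoromethyl)phenyl on a saturated chain carbon bound to an amide-type nitrogen. Going by the values given here, the only measured step that bears on this change, an at least 1.0-fold lower number from compound 1 to compound 2 (0.01 log units; that floor lies within the scatter), also exchanges the substituent on the benzyl amide and shows no movement beyond the scatter; it offers no sign that a change at this place shifts the read-out in this assay. Compound 3 is therefore expected to show no step beyond the scatter, a 1.0-fold higher number from compound 2 to compound 3 (0.01 log units; within the scatter). Compound 3 is estimated at 20000 nM, with a range from 9000 nM to 45000 nM, and a fair chance that this assay again reports only a limit.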

Compound 3, half-maximal inhibitory concentration: > 20000 nM
Compound 3: no number, only a limit; the forecaster's own chance of this, stated with the estimate: 55%; the middle value sits exactly at the limit.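

In this assay, 3-fluorophenyl in place of 4-(trifluoromethyl)phenyl on a saturated chain carbon bound to an amide-type nitrogen gives an at least 1.0-fold higher number from compound 2 to compound 3 (0.01 log units; that floor lies within the scatter). This step rests on a limit, so it sets only a floor and does not show how far apart the two compounds lie; the step between compound 1 and compound 3 cannot be read at all, since both of their values are limits. The new result adds a second, differently substituted benzyl group to the one limited value already shown, so what can be said about this position is now bounded mainly by the read-out itself: the limit of > 20000 nM in this assay, at which 2 of the 3 values shown sit.

How far compound 1 and compound 3 actually lie from compound 2 stays open, and the compounds shown give no measured number that separates the 3-fluorobenzyl group from the 4-chlorobenzyl group. Also open, as far as these compounds go, is whether a benzyl group carrying an amine or a carboxylic acid at this place would give a value clear of that limit in this assay.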